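Vero cytotoxicity notes: the step from compound 2 to compound 3

The source may report more compounds than this note shows. Statements on the series, on what has been measured and on what is new or still open speak of the compounds shown alone.

Measured so far:
compound 1 `CN1Cc2ccc(OCc3ccccc3)cc2[C@@H](O)C1` gives > 100000 nM
compound 2 `CN1Cc2ccc(OCCc3ccccc3)cc2[C@@H](O)C1` gives > 50000 nM

In an ADME assay on Vero cells (Chlorocebus sabaeus) for cytotoxicity, read by sulforhodamine B assay, with a stated time of 72 h (on this read-out higher numbers stand for weaker inhibition and lower numbers for stronger inhibition), compound 1 gives > 100000 nM, which is a limit of the assay and not a number. In this assay compound 2 gives > 50000 nM, also a limit of the assay. The step that the two limits leave unreadable from compound 1 to compound 2 cannot be read, since one value sits at the limit of > 100000 nM in this assay, at which 1 of the 2 values shown sits, and the other at the limit of > 50000 nM in this assay, at which 1 of the 2 values shown sits. Compound 2 therefore stands only at a limit on the numbers shown.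

Compound 3 `CN1Cc2ccc(OCC3CCCCC3)cc2[C@@H](O)C1` differs from compound 2 by cyclohexyl in place of benzyl on a saturated chain carbon bound to an oxygen on an aromatic ring. Among the measured compounds shown here, the only measured step that bears on this change is a step that the two limits leave unreadable from compound 1 to compound 2, and it gives no readable size. No step beyond the usual scatter is expected, so the estimated step is a step that the limit leaves unreadable from compound 2 to compound 3. For compound 3 in this assay the estimate is 100000 nM, with a range from 40000 nM to 300000 nM, and most likely again only a limit is reported.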

Compound 3, half-maximal inhibitory concentration: 65600 nM
Estimate against measurement, compound 3: 1.5-fold (0.18 log units) above, within the range that was stated.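

In this assay, among the compounds shown here, compound 3 gives 65600 nM, the first value at this position that is a number and not a limit of the assay. The change of phenyl to cyclohexyl on a saturated chain carbon bound to an oxygen on an aromatic ring reads as an at least 1.5-fold lower number from compound 1 to compound 3 (0.18 log units; that floor lies within the scatter), so this comparison supports no claim of a real change. The step from benzyl to cyclohexyl cannot be read because compound 2 stands at a limit of the assay: the limit of > 50000 nM in this assay, at which 1 of the 3 values shown sits.

On these data alone, whether compound 2 and compound 3 differ in this read-out stays open. Also open, as far as these compounds go, is what a longer chain carrying cyclohexyl, or an amine or a carboxylic acid in its place, would give in this assay.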